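A few compounds are considered here, and "the series" means these few. Any claim that something is new, unique, unknown or untested is made for them only; others in the source may bear on it.

Measured compounds:
compound 1 `COc1ccc(/C=C\C(=O)O)c(OCc2cn(-c3cccc(C#N)c3)nn2)c1CC=C(C)C`, 19200 nM
compound 2 `COc1ccc(/C=C\C(=O)O)c(OCc2cn(-c3ccccc3C(=O)N3CCC(O)C3)nn2)c1CC=C(C)C`, 13400 nM

Both were read in a functional assay on T47D cells (Homo sapiens) for cytotoxicity, read by MTT assay, with a stated time of 24 h; on this read-out higher numbers stand for weaker inhibition and lower numbers for stronger inhibition. Of the two numbers, compound 1 has the higher one; compound 2 lies within the usual scatter of it, so no order between them can be claimed. Compound 3 `COc1ccc(/C=C\C(=O)O)c(OCc2cn(-c3nc4ccccc4s3)nn2)c1CC=C(C)C` is not yet measured in this assay. It differs from compound 1 by 1,3-benzothiazol-2-yl in place of 3-cyanophenyl on an aromatic nitrogen. For the measured compounds named here, with no comparable step recorded, the change from compound 1 to compound 3 is expected to stay within the scatter, with no clear direction, so the step of a 1.2-fold lower number from compound 1 to compound 3 (0.08 log units; within the scatter) is expected to be small. Compound 3 is expected to give about 16000 nM, within a range from 6000 nM to 45000 nM.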

Compound 3, half-maximal inhibitory concentration: 17200 nM
The estimate for compound 3 lay 1.1-fold (0.03 log units) below the measured number; the range from low to high includes it.
By their numbers in this assay, from the lowest: compounds 2, 3 and 1 (each within the scatter of the next).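

At the aromatic nitrogen of the five-membered ring with 3 nitrogen, 1,3-benzothiazol-2-yl in place of 3-cyanophenyl gives a 1.1-fold lower number from compound 1 to compound 3 (0.05 log units; within the scatter) in this assay as the first step read at this position. The position therefore takes a group with two aromatic rings and no nitrile while the number stays within the scatter. As far as these compounds go, whether an amine, a carboxylic acid or a simple alkyl chain at this position would move the number beyond the scatter remains open. Nothing available explains why this step is small.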